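Taking Away One Methoxy Group

The source may hold more compounds than are shown below. What is called first, only, known or untested is meant among the compounds shown, and "the series" means these compounds.

Compound 1 `COc1ccc(/C=C/C(=O)c2ccncc2)cc1OC` was tested in an assay on HEK293 cells for inhibition of cytochrome P450 1A1 (Homo sapiens), read by fluorescence, with stated times of 30 min and 60 min (on this read-out higher numbers stand for weaker inhibition and lower numbers for stronger inhibition), where compound 1 gives 420 nM. Going by the values given here, this is the higher of the two numbers measured so far. Compound 2 `COc1cc(/C=C/C(=O)c2ccncc2)cc(OC)c1OC`, which carries one more methoxy group, gives 58 nM in this assay, a step of a 7.2-fold lower number from compound 1 to compound 2 (0.86 log units; beyond the scatter), methoxy in place of hydrogen on an aromatic carbon. The unmeasured compound 3 `COc1cccc(/C=C/C(=O)c2ccncc2)c1` goes the opposite way from compound 1: hydrogen in place of methoxy on an aromatic carbon. Among the compounds with values here, only that one measured step bears on this change, and it runs in the reverse direction, so removing a methoxy group is expected to raise the number in this assay, a step of a 4.8-fold higher number from compound 1 to compound 3 (0.68 log units; beyond the scatter), although a single step is thin ground for such an extrapolation. For compound 3 the expected value in this assay is 2000 nM, within 600 nM to 7000 nM.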

Compound 3, half-maximal inhibitory concentration: 620 nM
Beside the measured number, compound 3's estimate is 3.2-fold (0.51 log units) above it, within the range that was stated.
By their numbers in this assay, from the lowest: compound 2; then compounds 1 and 3 (each within the scatter of the next).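

Taking this methoxy group away, at the place ortho to a methoxy group and para to a large group, makes no clear difference in this assay: the result is a 1.5-fold higher number from compound 1 to compound 3 (0.17 log units; within the scatter). Methoxy and hydrogen therefore cannot be told apart at this place, unlike the methoxy added at a different place on the same ring, where the result is a 7.2-fold lower number from compound 1 to compound 2 (0.86 log units; beyond the scatter), beyond the scatter. Nothing available here bears on why these two places differ.

Going by these compounds, it remains open whether this place would accept groups other than hydrogen and methoxy, such as an amine, a chlorine atom or a longer ethoxy chain. On these data alone, it is also open how the number would respond if the methoxy group remaining on compound 3 were replaced.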